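The source may hold more compounds than are shown below. What is called first, only, known or untested is meant among the compounds shown, and "the series" means these compounds.

Of the compounds shown here, two built on a shared core have been measured so far in a functional assay on SMMC-7721 cells (Homo sapiens) for antiproliferative activity, read by MTT assay, with a stated time of 48 h; on this read-out higher numbers stand for weaker inhibition and lower numbers for stronger inhibition. Compound 1 (`CC(=O)OC/C1=C/C[C@](C)(CCC=C(C)C)/C=C/[C@@H](OC(=O)C=C(C)C)[C@](C)(O)/C=C/C1=O`) gives 2950 nM, and compound 2 (`CO/N=C/C1=C/C[C@](C)(CCC=C(C)C)/C=C/[C@@H](OC(=O)C=C(C)C)[C@](C)(O)/C=C/C1=O`) gives 3470 nM, which places compound 2 level with compound 1 within the scatter of repeated measurements. Compound 3 (`CCN(CC)C(=O)/C1=C/C[C@](C)(CCC=C(C)C)/C=C/[C@@H](OC(=O)C=C(C)C)[C@](C)(O)/C=C/C1=O`) has not yet been measured in this assay. It departs from compound 2 by a single exchange: a group of 7 heavy atoms (5 carbon, 1 nitrogen, 1 oxygen; no ring) in place of a group of 4 heavy atoms (2 carbon, 1 nitrogen, 1 oxygen; no ring), on a double-bonded ring carbon. The incoming group is a diethylcarbamoyl, attached on a double-bonded ring carbon. Going by the values given here, only one measured step bears on this change, a 1.2-fold higher number from compound 1 to compound 2 (0.07 log units; within the scatter), which also exchanges the group on a double-bonded ring carbon. Neither compound 1 nor compound 2 carries a diethylcarbamoyl group, so the data offer only indirect guidance, and the range must stay wide. Among the compounds with values here, with that one step as the sole guide, the expectation is no shift beyond the scatter, and the estimated change is a 1.2-fold higher number from compound 2 to compound 3 (0.06 log units; within the scatter). For compound 3 the expected value is 4000 nM, with an estimated range from 1500 nM to 11000 nM.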

Compound 3, half-maximal inhibitory concentration: 13800 nM
For compound 3 the middle estimate is 3.5-fold (0.54 log units) below the measured one; measured number above the stated range.
By their numbers in this assay, from the lowest: compounds 1 and 2 (each within the scatter of the next); then compound 3.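

In this assay, the double-bonded ring carbon no longer looks indifferent to what it carries. The two earlier groups stood level within the scatter, whereas diethylcarbamoyl brings a 4.0-fold higher number from compound 2 to compound 3 (0.60 log units; beyond the scatter) and a 4.7-fold higher number from compound 1 to compound 3 (0.67 log units; beyond the scatter) and so makes compound 3 the weakest of the three, though both steps are modest. The compounds offer no measured information that would explain this loss of inhibition, so the result stands as an observation about this one exchange.

From the compounds shown here alone, it remains open whether the higher number belongs to the two ethyl groups on the amide nitrogen or to the carbonyl attached directly to the ring carbon, a question that a dimethylcarbamoyl group, an unsubstituted carbamoyl group or a carboxylic acid at this place could help to separate. Going by these compounds, it also remains open whether any other group on this carbon, such as a simple amine or a longer chain, could take the number clearly under the level shared by compound 1 and compound 2, or whether that level is the best this position allows.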